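The source may hold more compounds than are shown below. What is called first, only, known or untested is meant among the compounds shown, and "the series" means these compounds.

Measured so far in a functional assay on MCF7 cells (Homo sapiens) for inhibition, read by fluorescence, with a stated time of 72 h; a lower number here means a stronger inhibitor, a higher number a weaker inhibitor:
Compound 1 `Cn1cnc2c(NC(=N)N)ncnc21` gives > 100000 nM, a limit of the assay rather than a number.
Compound 2 `CC(C)n1cnc2c(N)nc(N)nc21` gives > 100000 nM, again a limit of the assay.
Compound 3 `CC(C)n1cnc2c(NC(=N)N)nc(NCCCO)nc21` gives 8800 nM.

Going by the values given here, compound 3 therefore carries the only numerical value in this set; the other two values sit at the limit of > 100000 nM in this assay, at which 2 of the 3 values shown sit. Among the compounds with values here, no two measured compounds differ in a single place, so no measured step is available to calibrate against. Compound 4 `CC(C)n1cnc2c(NC(=N)N)nc(NC3CC3)nc21` differs from compound 3 by cyclopropyl in place of 3-hydroxypropyl on a nitrogen on an aromatic ring. Nothing measured shows what this exchange is worth here. In this assay the change is expected to shift compound 4 only modestly, within or just beyond the usual scatter, with the direction uncertain. Compound 4 is estimated at 8000 nM, between 3000 nM and 25000 nM. That amounts to an expected step of a 1.1-fold lower number from compound 3 to compound 4 (0.04 log units; within the scatter).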

Compound 4, half-maximal inhibitory concentration: 5400 nM
Compound 4: the middle estimate sits 1.5-fold (0.17 log units) above what was measured; measured number inside the range.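

In this assay, this place now has its first measured step, a 1.6-fold lower number from compound 3 to compound 4 (0.21 log units; within the scatter), and it lies within the scatter. Cyclopropyl and 3-hydroxypropyl on a nitrogen on an aromatic ring therefore cannot be told apart here, so the hydroxyl-bearing chain is not required for a numerical value in this pair. The data shown give no cause for the step. Going by these compounds, whether a longer chain, a carboxylic acid or a morpholine on this nitrogen would move the number beyond the scatter remains open.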